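Cytotoxicity series on Vero cells: step to compound 4

A few compounds are considered here, and "the series" means these few. Any claim that something is new, unique, unknown or untested is made for them only; others in the source may bear on it.

Measured so far in an ADME assay on Vero cells (Chlorocebus sabaeus) for cytotoxicity, read by neutral red uptake, tested at 25 ug/mL; a higher number here means a weaker effect of the compound at the concentration tested, a lower number a stronger effect:
- compound 1 `COc1ccc(C2SCC(=O)N2CCN2CCCCC2)cc1`: 100%
- compound 2 `O=C1CSC(c2ccc(O)cc2)N1CCN1CCCCC1`: 100%
- compound 3 `COc1cccc(C2SCC(=O)N2CCN2CCCCC2)c1`: 97%

Compound 2 stands level with compound 1 at the digits shown, the two together the highest of the three numbers; compound 3 lies a little lower, within the scatter. For the measured compounds named here, the only single-point step measured so far, no change at the digits printed from compound 1 to compound 2 (within the scatter), is flat.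

Compound 4 `O=C1CSC(c2ccccc2Cl)N1CCN1CCCCC1` is unmeasured. The change from compound 2 is 2-chlorophenyl in place of 4-hydroxyphenyl on a saturated ring carbon. Going by the values given here, no measured step touches this change: the one step known concerns only the hydroxyl against methoxy and was within the scatter. Among the compounds with values here, with every number so far at or near the top of the scale, compound 4 is expected to behave the same, a number 3 percentage points lower from compound 2 to compound 4 (within the scatter), no change beyond the scatter. The estimate for compound 4 in this assay is therefore 97%, with a range from 85% to 104%.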

Compound 4, a percentage reported as activity, at one concentration (the size of the read-out at that concentration, not a potency): 100%
Estimate against measurement, compound 4: 3 percentage points below; low and high end bracket the measured number.
By their numbers in this assay, from the lowest: compounds 3, 1, 2 and 4 (each within the scatter of the next).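

In this assay, 2-chlorophenyl in place of 4-hydroxyphenyl on the saturated ring carbon gives no change at the digits printed from compound 2 to compound 4 (within the scatter). The earlier step touched only the group on the oxygen, whereas this change exchanges the whole aromatic substituent, and the read-out stays flat with the hydrogen-bond donor and acceptor of 4-hydroxyphenyl gone and chlorine present. No evidence at hand bears on this flat result. Still open, going by these compounds, is whether an amine or a carboxylic acid on the aromatic ring would move the read-out. No group shown at this position has yet shifted it beyond the scatter.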